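A few compounds are considered here, and "the series" means these few. Any claim that something is new, unique, unknown or untested is made for them only; others in the source may bear on it.

Of the compounds shown here, three have been measured so far in a functional assay on DU-145 cells (Homo sapiens) for inhibition, read by trypan blue exclusion, with a stated time of 96 h; on this read-out lower numbers stand for stronger inhibition of growth and higher numbers for weaker inhibition of growth. Compound 1, with the structure `O=C(/C(=C\c1ccc(O)cc1)S(=O)(=O)Cc1ccc(Cl)c(Cl)c1)c1ccc(Cl)cc1`, gives 10000 nM in this assay. Compound 2, with the structure `Cc1ccc(CS/C(=C/c2c[nH]c3ccc(Cl)cc23)C(=O)c2ccc(Cl)cc2)cc1`, gives 1000 nM in this assay. Compound 3, with the structure `Cc1ccc(S/C(=C/c2cc(Cl)cc(Cl)c2Cl)C(=O)c2ccc(Cl)cc2)cc1`, gives 50000 nM in this assay. Among these three, compound 2 stands with the lowest number, and its steps to both others are beyond the scatter: compound 1 is nearest to it and compound 3 furthest from it.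

Compound 4, with the structure `Cc1ccc(CS/C(=C/c2c[nH]c3ccc(Br)cc23)C(=O)c2ccc(Cl)cc2)cc1`, has not yet been measured in this assay. It differs from compound 2 in one place: bromo in place of chloro on an aromatic carbon. Cut one bond further out, the change reads 5-chloro-1H-indol-3-yl to 5-bromo-1H-indol-3-yl. Within the data shown here, no step between measured compounds shows such a swap, so the expectation rests on the change being a single halogen for another. The step from compound 2 to compound 4 is expected to stay within the scatter, which is estimated as a 1.1-fold lower number from compound 2 to compound 4 (0.05 log units; within the scatter). Compound 4 is therefore estimated at 900 nM, with a range from 300 nM to 2700 nM.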

Compound 4, concentration for 50% growth inhibition: 1000 nM
Compound 4: middle estimate off by 1.1-fold (0.05 log units), on the low side, and the stated range covers the measured number.
By their numbers in this assay, from the lowest: compounds 2 and 4 (each within the scatter of the next); then compound 1; then compound 3.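

In this assay, going from 5-chloro-1H-indol-3-yl to 5-bromo-1H-indol-3-yl gives no change at the digits printed from compound 2 to compound 4 (within the scatter), so at this position on the ring either halogen fits with no change that can be told apart from repeat scatter. Among these compounds, no two of the earlier compounds differed in one place only, which makes this the first single change that can be read on its own. Nothing available here explains why the two halogens read alike.

Still open, on these data alone, is whether this position accepts anything other than these two halogens, such as an amine, a methoxy group or a carboxylic acid, or no substituent at all. Also open, as far as these compounds go, is how a single change elsewhere in the molecule would read, for example on the benzyl group attached through sulfur.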